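From propyl to 2-hydroxyethyl in compound 4

The source may hold more compounds than are shown below. What is called first, only, known or untested is meant among the compounds shown, and "the series" means these compounds.

Measured in a functional assay on HCT-116 cells (Homo sapiens) for antiproliferative activity, read by sulforhodamine B assay, with a stated time of 72 h; a higher number here means a weaker inhibitor, a lower number a stronger inhibitor:
- compound 1 `Cn1ncc(Cl)c1-c1cc(C(=O)N[C@@H]2CN[C@H](CC(=O)O)C[C@H]2c2ccc(Cl)c(Cl)c2)oc1Cl`: 4020 nM
- compound 2 `Cn1ncc(Cl)c1-c1cc(C(=O)N[C@@H]2CN[C@H](CC(=O)NCC(O)CO)C[C@H]2c2ccc(Cl)c(Cl)c2)oc1Cl`: 7090 nM
- compound 3 `CCC[C@@H]1C[C@@H](c2ccc(Cl)c(Cl)c2)[C@H](NC(=O)c2cc(-c3c(Cl)cnn3C)c(Cl)o2)CN1`: 1020 nM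

Compound 3 holds the lowest number of the three, and its gaps to compound 1 and compound 2 both lie beyond the scatter. Compound 4 `Cn1ncc(Cl)c1-c1cc(C(=O)N[C@@H]2CN[C@H](CCO)C[C@H]2c2ccc(Cl)c(Cl)c2)oc1Cl` keeps the shared core and differs from compound 3 in one place: hydroxy in place of methyl on a saturated chain carbon, two bonds along the chain from a saturated ring carbon. This is hydroxy in place of methyl on a saturated chain carbon, two bonds along the chain from a saturated ring carbon, so propyl becomes 2-hydroxyethyl.

Among the measured compounds shown here, no measured step makes this exact change. The closest guides are the two steps that alter the same side chain and end at compound 3: a 3.9-fold lower number from compound 1 to compound 3 (0.60 log units; beyond the scatter), and a 7.0-fold lower number from compound 2 to compound 3 (0.84 log units; beyond the scatter). The remaining step, a 1.8-fold higher number from compound 1 to compound 2 (0.25 log units; within the scatter), separates the two oxygen-bearing chains by no more than the scatter. Compound 1 and compound 2 both carry oxygen on this chain and both give higher numbers than compound 3, though three compounds are a thin basis. A modest rise in this assay is therefore expected, no larger than those two steps. The expected change is a 2.3-fold higher number from compound 3 to compound 4 (0.35 log units; beyond the scatter). For compound 4 the estimate is 2300 nM, with an expected range of 1000 nM to 5200 nM.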

Compound 4, half-maximal inhibitory concentration: 340 nM
Beside the measured number, compound 4's estimate is 6.8-fold (0.83 log units) above it, and the stated range ends above it.
By their numbers in this assay, from the lowest: compound 4; then compound 3; then compounds 1 and 2 (each within the scatter of the next).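

In this assay there is a 3.0-fold lower number from compound 3 to compound 4 (0.48 log units; beyond the scatter), so hydroxy in place of methyl, on a saturated chain carbon two bonds along the chain from a saturated ring carbon, makes compound 4 the strongest inhibitor of the four. Compound 1 and compound 2 had linked oxygen on this side chain to higher numbers, but compound 4 goes against that link, with a 12-fold lower number from compound 1 to compound 4 (1.07 log units; beyond the scatter) and a 21-fold lower number from compound 2 to compound 4 (1.32 log units; beyond the scatter), so oxygen on this chain does not in itself raise the number, and the outcome depends on which oxygen-bearing group is present. Nothing available here bears on what lies behind these differences.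

The compounds shown leave open whether the gain belongs to the hydroxy itself or to where it sits, and a longer chain ending in hydroxy, a methyl ether or a primary amine at the same place would each bear on that question. They also leave open whether the same change would lower the number on a core carrying a different group in place of the dichlorophenyl ring.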